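A few compounds are considered here, and "the series" means these few. Any claim that something is new, unique, unknown or untested is made for them only; others in the source may bear on it.

Compound 1 `CC(=O)Nc1ccc([N+](=O)[O-])cc1OCc1ccccc1` gives 1180 nM in an assay on SK-BR-3 cells for inhibition of Aromatase (Homo sapiens); a lower number here means a stronger inhibitor, a higher number a weaker inhibitor. Compound 2 `O=C(Nc1ccc([N+](=O)[O-])cc1OCc1ccccc1)c1ccc([N+](=O)[O-])cc1` gives > 25000 nM, which is a limit of the assay rather than a number.

So compound 2 stands at the limit of > 25000 nM in this assay, at which 1 of the 2 values shown sits, with no exact number. Compound 3 `O=C(Nc1ccc([N+](=O)[O-])cc1OCc1ccccc1)c1ccc(Cl)c([N+](=O)[O-])c1` differs from it in one change: 4-chloro-3-nitrophenyl in place of 4-nitrophenyl on a carbonyl carbon. Among the measured compounds shown here, the only measured step, an at least 21-fold higher number from compound 1 to compound 2 (1.32 log units; beyond the scatter), bears on this indirectly, as it shows that an aryl ring on this carbonyl carbon already gives a much weaker result. A change within that aryl ring is expected to leave compound 3 at the limit too, so the expected step that the limit leaves unreadable from compound 2 to compound 3 is small. Compound 3 is estimated at 30000 nM, in a range from 8000 nM to 120000 nM.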

Compound 3, half-maximal inhibitory concentration: > 25000 nM
Compound 3 was reported as a limit; the forecaster's own chance of this, stated with the estimate: 70%; the middle value does not contradict the limit.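

Compared with the methyl of compound 1, 4-chloro-3-nitrophenyl on this carbonyl carbon gives an at least 21-fold higher number from compound 1 to compound 3 (1.32 log units; beyond the scatter) in this assay. The large loss seen with 4-nitrophenyl therefore also appears with a second substituted phenyl ring. The step between compound 2 and compound 3 cannot be read, because both values are limits of the assay and not numbers: the limit of > 25000 nM in this assay, at which 2 of the 3 values shown sit.

Still open, going by these compounds, is how much of the loss comes with any aryl ring at all. An unsubstituted phenyl or a small chain such as ethyl on this carbonyl carbon could show whether the result stays near that of compound 1 or also reaches the limit.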